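Quinolin-3-yl for pyridin-4-yl on the shared core

The source may report more compounds than this note shows. Statements on the series, on what has been measured and on what is new or still open speak of the compounds shown alone.

Measured in a functional assay on NCI-H1993 cells (Homo sapiens) for inhibition, read by CCK-8 assay, with a stated time of 72 h; on this read-out higher numbers stand for weaker inhibition and lower numbers for stronger inhibition
- compound 1 `Cc1c(C(C)n2cnc3ncc(-c4cn[nH]c4)nc32)ccc2ncccc12` gives 599 nM
- compound 2 `Cc1c(C(C)n2cnc3ncc(-c4ccncc4)nc32)ccc2ncccc12` gives 950 nM

Among the compounds with values here, compound 2, at 950 nM, lies within the scatter of compound 1, the only other measured value. Compound 3 `Cc1c(C(C)n2cnc3ncc(-c4cnc5ccccc5c4)nc32)ccc2ncccc12` carries quinolin-3-yl in place of pyridin-4-yl on an aromatic carbon. Within the data shown here, one measured step bears on this place, the exchange of 1H-pyrazol-4-yl for pyridin-4-yl, a 1.6-fold higher number from compound 1 to compound 2 (0.20 log units; within the scatter). Among the measured compounds shown here, no measured step covers a group of this size, so the range stays wide. In this assay the expected change is a 1.1-fold higher number from compound 2 to compound 3 (0.02 log units; within the scatter), with no step beyond the scatter anticipated. For compound 3 the estimated value is 1000 nM, with an expected range from 300 nM to 3300 nM.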

Compound 3, half-maximal inhibitory concentration: 450 nM
Compound 3: middle estimate off by 2.2-fold (0.35 log units), on the high side, within the range that was stated.
By their numbers in this assay, from the lowest: compounds 3, 1 and 2 (each within the scatter of the next, the first and the last beyond it).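

In this assay, within the data shown here, this aromatic carbon accepts quinolin-3-yl, with its added six-membered aromatic ring of carbon only, and the exchange gives the first step beyond the scatter, a 2.1-fold lower number from compound 2 to compound 3 (0.32 log units; beyond the scatter), though only a modest one. Against 1H-pyrazol-4-yl the same group shows a 1.3-fold lower number from compound 1 to compound 3 (0.12 log units; within the scatter), so it stands level with that smaller ring, not ahead of it. No data at hand explain the step. Open, going by these compounds, is how an amine or a carboxylic acid would fare at this place. Also open, on these data alone, is whether a phenyl ring, without ring nitrogen, would match quinolin-3-yl.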